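A Nitro Group Moved Around the Benzyl Ring

The compounds below may be only part of what the source reports. "The series", "measured", "known", "first", "only" and "open" are said of these compounds alone.

In a functional assay on HepG2 cells (Homo sapiens) for inhibition, read by MTT assay, with a stated time of 48 h (on this read-out higher numbers stand for weaker inhibition and lower numbers for stronger inhibition), compound 1 `Clc1ccccc1CSc1nnc(-c2ccncc2)n1-c1ccccc1` gives 15700 nM. Compound 2 `O=[N+]([O-])c1ccccc1CSc1nnc(-c2ccncc2)n1-c1ccccc1` reaches only the assay limit of > 50000 nM, a limit and not a number (the limit of > 50000 nM in this assay, at which 1 of the 2 values shown sits). Among the measured compounds shown here, the single measured step, an at least 3.1-fold higher number from compound 1 to compound 2 (0.50 log units; beyond the scatter), swaps one group for another rather than moving a group, so it does not cover the change to compound 3 `O=[N+]([O-])c1ccc(CSc2nnc(-c3ccncc3)n2-c2ccccc2)cc1`, which is 4-nitrophenyl in place of 2-nitrophenyl on a saturated chain carbon bound to a sulfur. For the measured compounds named here, with no step of the same kind, the data give no direction for this move. Compound 3 is therefore expected to stay weak, with an estimated 40000 nM between 12000 nM and 130000 nM. The expected step is then an at least 1.2-fold lower number from compound 2 to compound 3 (0.09 log units; that floor lies within the scatter).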

Compound 3, half-maximal inhibitory concentration: > 50000 nM
Compound 3 gave a limit, no number; the forecaster's own chance of this, stated with the estimate: 55%; middle value at least 1.2-fold (0.09 log units) from the limit.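

Replacing 2-chlorophenyl with 4-nitrophenyl on the saturated chain carbon bound to a sulfur gives an at least 3.1-fold higher number from compound 1 to compound 3 (0.50 log units; beyond the scatter) in this assay. A nitro group therefore falls short of the chloro compound in both of the places shown, not only in 2-nitrophenyl. The step between the two nitro isomers cannot be read, since both ends are limits and not numbers: the limit of > 50000 nM in this assay, at which 2 of the 3 values shown sit.

Going by these compounds, how far compound 2 and compound 3 lie beyond that limit stays open. So does whether an amine or a carboxylic acid in place of the nitro group would give a measurable value.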